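Swapping octylsulfanyl for isobutylamino on a weakly toxic compound

The compounds below may be only part of what the source reports. "The series", "measured", "known", "first", "only" and "open" are said of these compounds alone.

Compound 1 `CNc1nc(N)nc2c1ncn2/C=C1/CC1(CO)CO`: > 20000 nM, a limit and not a number
Compound 2 `CCCCCCCCSc1nc(N)nc2c1ncn2/C=C1/CC1(CO)CO`: 60000 nM

Among the measured compounds shown here, in an ADME assay on CCRF-HSB-2 cells (Homo sapiens) for cytotoxicity, with a stated time of 7 days (on this read-out lower numbers stand for higher toxicity in this test and higher numbers for lower toxicity in this test), compound 2 gives 60000 nM, the only true number so far. Compound 1 offers only (the limit of > 20000 nM in this assay, at which 1 of the 2 values shown sits).

The next compound is compound 3 `CC(C)CNc1nc(N)nc2c1ncn2/C=C1/CC1(CO)CO`. Its change is isobutylamino in place of octylsulfanyl on an aromatic carbon. For the measured compounds named here, compound 1 carries methylamino at that same place, so the one measured step bears directly on this change. That step is a step that the limit leaves unreadable from compound 1 to compound 2, which gives no size to carry over. No shift beyond the scatter can therefore be expected in this assay, in either direction. The expected step is a 1.3-fold lower number from compound 2 to compound 3 (0.12 log units; within the scatter). For compound 3 the estimated value is 45000 nM, with an expected range from 18000 nM to 110000 nM. The assay may well report only a limit for this compound.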

Compound 3, half-maximal cytotoxic concentration: > 20000 nM
Compound 3: only a limit was reported; the forecaster's own chance of this, stated with the estimate: 55%; the middle value is on the limit's open side.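

In this assay, among the compounds shown here, compound 3 gives > 20000 nM, a limit and not a number, so no step among compound 1, compound 2 and compound 3 can be read. The compounds shown leave open whether methylamino, isobutylamino and octylsulfanyl differ at all in toxicity to these cells, with most values sitting at one limit: the limit of > 20000 nM in this assay, at which 2 of the 3 values shown sit.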